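Hydroxyamino in place of methoxyamino on the pyridine amide

The source may hold more compounds than are shown below. What is called first, only, known or untested is meant among the compounds shown, and "the series" means these compounds.

Compound 1 `CONC(=O)c1ccccn1` stands at the limit of an ADME assay on Huh-7 cells (Homo sapiens) for cytotoxicity, read by MTT assay, with a stated time of 72 h; a lower number here means that less compound is tolerated, a higher number that more compound is tolerated: in this assay compound 1 gives > 1000000 nM, a limit of the assay and not a number. Compound 2 `O=C(NO)c1ccncc1` in this assay gives 210000 nM. Compound 3 `O=C(NO)c1ccccn1` is the unmeasured partner of compound 1, differing by hydrogen in place of methyl on an oxygen. Among the measured compounds shown here, no measured step covers this pair, so its size is only expected: the step from compound 1 to compound 3 is expected to be a moderate decrease, an at least 2.5-fold lower number from compound 1 to compound 3 (0.39 log units; beyond the scatter), since compound 2 with the same hydroxyamino group gives 210000 nM. Compound 3 is therefore estimated at 400000 nM, within 120000 nM to 1000000 nM.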

Compound 3, half-maximal cytotoxic concentration: 710000 nM
Compound 3: middle estimate off by 1.8-fold (0.25 log units), on the low side, and the stated range covers the measured number.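

In this assay, among the compounds shown here, the change from methoxyamino to hydroxyamino reads as an at least 1.4-fold lower number from compound 1 to compound 3 (0.14 log units; that floor lies within the scatter) and gives the first measured step at this oxygen, though a floor of this size does not yet establish a real drop. Compound 1 gives > 1000000 nM as a limit of the assay and not a number. The step can be read only as a floor, because one end of the pair is capped: the limit of > 1000000 nM in this assay, at which 1 of the 3 values shown sits.

Still open, as far as these compounds go, are the true size of this step and how an ethoxyamino group, a longer chain on this oxygen or an amine in place of the hydroxyamino group would read.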